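A few compounds are considered here, and "the series" means these few. Any claim that something is new, unique, unknown or untested is made for them only; others in the source may bear on it.

Series notes, side-chain ester variation on the shared core.

Compound 1 `C=C(C)CC(=O)O[C@H]1C[C@@H](C)C=C2C=C[C@H](C)[C@H](CC[C@@H]3C[C@@H](O)CC(=O)O3)C21` carries the 2-methylprop-2-en-1-yl ester; in an assay for inhibition of 3-hydroxy-3-methylglutaryl-coenzyme A reductase (Rattus norvegicus) (a lower number here means a stronger inhibitor, a higher number a weaker inhibitor), compound 1 gives 2.9 nM, the highest of the three numbers recorded so far. Compound 2 `C[C@H]1C=C2C=C[C@H](C)[C@H](CC[C@@H]3C[C@@H](O)CC(=O)O3)C2[C@@H](OC(=O)C(C)(C)C)C1` gives 2.7 nM, and compound 3 `CCC(C)(CC)C(=O)O[C@H]1C[C@@H](C)C=C2C=C[C@H](C)[C@H](CC[C@@H]3C[C@@H](O)CC(=O)O3)C21` gives 1.4 nM. The steps among them are small: a 1.1-fold lower number from compound 1 to compound 2 (0.03 log units; within the scatter), a 2.1-fold lower number from compound 1 to compound 3 (0.32 log units; beyond the scatter), and a 1.9-fold lower number from compound 2 to compound 3 (0.29 log units; within the scatter). Among the compounds with values here, exchanging the alkyl part of the ester thus moves this assay little, and only the step to compound 3 clears the scatter.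

Compound 4 `C[C@H]1C=C2C=C[C@H](C)[C@H](CC[C@@H]3C[C@@H](O)CC(=O)O3)C2[C@@H](OC(=O)Oc2ccccc2)C1` is the next member. It differs from compound 1 by phenoxy in place of 2-methylprop-2-en-1-yl on a carbonyl carbon, so the ester becomes a carbonate bearing an aromatic ring. Within the data shown here, none of the measured steps carries this kind of change; they show only that substituents on the carbonyl carbon of varied size are tolerated within a narrow band. On that basis the expected step is a 1.2-fold higher number from compound 1 to compound 4 (0.08 log units; within the scatter), with the wider uncertainty reflecting the untested phenoxy. For compound 4 the estimated value in this assay is 3.5 nM, with a range from 1.2 nM to 12 nM.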

Compound 4, half-maximal inhibitory concentration: 83 nM
Beside the measured number, compound 4's estimate is 24-fold (1.38 log units) below it, outside the stated range (above it).
By their numbers in this assay, from the lowest: compounds 3, 2 and 1 (each within the scatter of the next, the first and the last beyond it); then compound 4.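

In this assay the substituent on the carbonyl carbon is not freely exchangeable: phenoxy gives (a 29-fold higher number from compound 1 to compound 4 (1.46 log units; beyond the scatter)), and it gives the same kind of large rise against the two other groups, (a 31-fold higher number from compound 2 to compound 4 (1.49 log units; beyond the scatter)) and (a 59-fold higher number from compound 3 to compound 4 (1.77 log units; beyond the scatter)). The narrow band held by 2-methylprop-2-en-1-yl, tert-butyl and 1-ethyl-1-methylpropyl therefore does not extend to this carbonate bearing an aromatic ring, and all three new steps point the same way. Nothing measured here speaks to the reason for this loss.

The change brings in an oxygen and an aromatic ring together, so the compounds shown do not tell which of the two goes with the higher number. Phenyl or methoxy on the same carbonyl carbon would separate the two.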